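The compounds below may be only part of what the source reports. "The series", "measured", "known", "first", "only" and "open" are said of these compounds alone.

Measured so far in a physicochemical assay for lipophilicity, read by HPLC, at pH 7.5; on this read-out higher numbers stand for higher lipophilicity and lower numbers for lower lipophilicity:
- compound 1 `CC[C@@H](Nc1c(C#N)c(-c2ccc(-c3cccc(Cl)c3OC)cc2)nc2cnccc12)C(N)=O` gives 3.1
- compound 2 `CC[C@@H](Nc1c(C#N)c(-c2ccc(-c3ccccc3C)cc2)nc2cnccc12)C(N)=O` gives 3

Compound 2 stands lowest of the two numbers, and its nearest neighbour is compound 1, since the change from compound 1 to compound 2 was a number 0.10 log units lower from compound 1 to compound 2 (within the scatter), the swap of 2-methylphenyl in place of 3-chloro-2-methoxyphenyl on an aromatic carbon.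

Compound 3 `CC[C@@H](Nc1c(C#N)c(-c2ccc(-c3ccccc3C(C)C)cc2)nc2cnccc12)C(N)=O` differs from compound 2 in one place: isopropyl in place of methyl on an aromatic carbon. Among the measured compounds shown here, no measured step covers this kind of change; the only step known, from compound 1 to compound 2, exchanged one whole substituted phenyl for another and stayed within the scatter, so it gives no guide for the growth of a methyl into an isopropyl. Two added carbons on an aromatic ring commonly raise a value in this assay by a step beyond the scatter, so compound 3 is expected to read higher than compound 2 by a number 0.80 log units higher from compound 2 to compound 3 (beyond the scatter). The estimate for compound 3 is 3.8, with a likely range from 3.3 to 4.3.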

Compound 3, distribution coefficient: 3.5
For compound 3 the middle estimate is 0.30 log units above the measured one, within the range that was stated.
By their numbers in this assay, from the lowest: compounds 2 and 1 (each within the scatter of the next); then compound 3.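

Among the compounds shown here, changing methyl to isopropyl on an aromatic carbon, ortho to a large group, gives a number 0.50 log units higher from compound 2 to compound 3 (beyond the scatter) in this assay, the first change at this position to move the number clearly. Replacing the whole 3-chloro-2-methoxyphenyl group with 2-isopropylphenyl gives a number 0.40 log units higher from compound 1 to compound 3 (beyond the scatter), so compound 3 stands apart from both earlier compounds, which remain within the scatter of each other. Nothing available explains why these steps have this size.

Still open, going by these compounds, is how a longer chain such as n-propyl, a ring such as cyclopropyl, or a charged group such as an amine or a carboxylic acid would read in this assay at the same place. On these data alone, it is also open whether the step from methyl to isopropyl keeps its size on a phenyl ring that also carries a chlorine.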